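The Same Swap Carried Onto a Second Core

A few compounds are considered here, and "the series" means these few. Any claim that something is new, unique, unknown or untested is made for them only; others in the source may bear on it.

Of the compounds shown here, three have been measured in a functional assay on SiHa cells (Homo sapiens) for inhibition, read by sulforhodamine B assay; on this read-out higher numbers stand for weaker inhibition of growth and lower numbers for stronger inhibition of growth. Compound 1 `Cc1ccc2[nH]c(-c3ccc(-c4ccc(-c5cccc(Cl)c5)cc4)cc3)nc2c1` gives 3600 nM in this assay. Compound 2 `COc1ccc(-c2ccc(-c3ccc(-c4nc5cc(C)ccc5[nH]4)cc3)cc2)cc1OC` differs from compound 1 only by 3,4-dimethoxyphenyl in place of 3-chlorophenyl on an aromatic carbon, and in this assay compound 2 gives 3510 nM. That exchange made a 1.0-fold lower number from compound 1 to compound 2 (0.01 log units; within the scatter), so the two numbers cannot be told apart. Compound 3 `Oc1cccc2[nH]c(-c3ccc(-c4ccc(-c5cccc(Cl)c5)cc4)cc3)nc12` carries a different core; how its core differs from the core of compound 1 is not broken down here. In this assay compound 3 gives 8400 nM, the highest number of the three, standing beyond the scatter from both compound 1 and compound 2.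

Compound 4 `COc1ccc(-c2ccc(-c3ccc(-c4nc5c(O)cccc5[nH]4)cc3)cc2)cc1OC` has not yet been measured. It differs from compound 3 by 3,4-dimethoxyphenyl in place of 3-chlorophenyl on an aromatic carbon, the same change that separates compound 1 and compound 2, made at the same kind of place. Among the compounds with values here, the only guide to its size is the earlier pair, where the exchange left the number essentially where it was. Because the same exchange made a 1.0-fold lower number from compound 1 to compound 2 (0.01 log units; within the scatter), compound 4 is expected to show no change at the digits printed from compound 3 to compound 4 (within the scatter). That expectation rests on a single precedent and on the unexplained gap between the two cores, so it is held loosely. The estimate for compound 4 in this assay is 8400 nM, with a likely range from 3500 nM to 20000 nM.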

Compound 4, concentration for 50% growth inhibition: 1110 nM
Beside the measured number, compound 4's estimate is 7.6-fold (0.88 log units) above it; measured number below the stated range.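

Carried onto the second core, the exchange of 3-chlorophenyl for 3,4-dimethoxyphenyl gave a 7.6-fold lower number from compound 3 to compound 4 (0.88 log units; beyond the scatter) in this assay, so the size of this step did not transfer from one core to the other: the same change on two cores in this assay, a 1.0-fold lower number (0.01 log units; within the scatter) from compound 1 to compound 2 and a 7.6-fold lower number (0.88 log units; beyond the scatter) from compound 3 to compound 4, 7.4-fold (0.87 log units) apart, beyond the scatter of two such steps

With 3,4-dimethoxyphenyl held in place, the change of core gave a 3.2-fold lower number from compound 2 to compound 4 (0.50 log units; beyond the scatter), whereas with 3-chlorophenyl in place compound 1 gives 3600 nM and compound 3 gives 8400 nM, so the two cores rank in opposite order under the two groups. This rests on one pair per core and shows only that, in these four compounds, the effect of the exchange depends on the core; it does not show why, which part of the core is responsible, or how a further core would behave.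

Open, as far as these compounds go, is whether a phenyl group bearing a single methoxy, or one bearing an amine or a carboxylic acid, would give the same large step on the core of compound 3 and the same flat one on the core of compound 1. Also open, from the compounds shown here alone, is whether the step would survive with a methoxy group or an amine in place of the hydroxy group on the core of compound 3.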